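The compounds below may be only part of what the source reports. "The series", "measured", "known", "first", "only" and "open" are said of these compounds alone.

Measured compounds:
compound 1 `COCC(C(=O)N1CCN(c2cccc(C(F)(F)F)c2)CC1)N1C(=O)CCC1=O` — 50%
compound 2 `CC(C(=O)N1CCN(c2cccc(C(F)(F)F)c2)CC1)N1C(=O)CCC1=O` — 75%

Within the data shown here, compound 2 gives the highest of the two numbers so far in a functional assay on the whole organism (strain Swiss) with Mus musculus as the target, with a stated time of 1 h, at a dose of 100 mg/kg; on this read-out lower numbers stand for a weaker effect and higher numbers for a stronger effect at the one dose given; the nearest is compound 1, whose value is lower. Among the measured compounds shown here, the only measured step, a number 25 percentage points higher from compound 1 to compound 2 (beyond the scatter), concerns a change on the saturated chain of the shared core, not on the aromatic ring.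

Compound 3 `CC(C(=O)N1CCN(c2cccc(Cl)c2)CC1)N1C(=O)CCC1=O` is yet to be measured in this assay. It differs from compound 2 in one place: chloro in place of trifluoromethyl on an aromatic carbon. For the measured compounds named here, no measured step touches the aromatic ring or either of these groups, so the step from compound 1 to compound 2 does not bear on this change directly; it shows only that a single-group exchange elsewhere on the core can move the read-out by a modest amount. With no guide on the ring substituent, the working expectation for compound 3 is a value near that of compound 2, within or just beyond the scatter, in no settled direction. Compound 3 is therefore estimated at 70%, with a range of 45% to 90%. This estimate corresponds to an expected step of a number 5 percentage points lower from compound 2 to compound 3 (within the scatter).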

Compound 3, a percentage reported as activity, at one dose (the size of the read-out at that dose, not a potency): 50%
For compound 3 the middle estimate is 20 percentage points above the measured one; low and high end bracket the measured number.
By their numbers in this assay, from the lowest: compounds 1 and 3 (each within the scatter of the next); then compound 2.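

In this assay the substituent on the aromatic ring is shown to matter: a number 25 percentage points lower from compound 2 to compound 3 (beyond the scatter), so the aromatic carbon meta to a large group does not tolerate the exchange of trifluoromethyl for chloro without a change in the read-out. The only step available before, a number 25 percentage points higher from compound 1 to compound 2 (beyond the scatter), lay on the saturated chain, so the series now holds a change on the chain and a change on the aromatic ring that each move the read-out beyond the scatter, and of the two groups shown at this ring position, trifluoromethyl gives the higher number at the one dose given. No measurement at hand says why chloro gives the lower number here.

As far as these compounds go, whether a fluoro, a methyl, a methoxy or a nitrile at this ring position would give a number closer to that of compound 2 or to that of compound 3 remains open, as does the outcome of placing trifluoromethyl or chloro elsewhere on the aromatic ring. Also open, from the compounds shown here alone, is whether the steps on the chain and on the ring would add up in a single compound, and how an ethyl or a longer chain would fare in place of the methyl on the saturated chain.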